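Benzothiophene in place of phenethyl: a cytotoxicity outlook

The compounds below may be only part of what the source reports. "The series", "measured", "known", "first", "only" and "open" are said of these compounds alone.

Compound 1 `NC(=S)N1CCc2c(OCCCCCOc3ccc(Cl)cc3)cccc21` and compound 2 `O=C(CCc1ccccc1)NC(=S)N1CCc2c(OCCCCCOc3ccc(Cl)cc3)cccc21` share one core. In an ADME assay on Huh-7 cells (Homo sapiens) for cytotoxicity (a higher number here means that more compound is tolerated, a lower number that less compound is tolerated), compound 1 gives only a limit, > 50000 nM. In this assay compound 2 also gives only a limit, > 50000 nM. The step that the two limits leave unreadable from compound 1 to compound 2 has no readable size because of the limit of > 50000 nM in this assay, at which 2 of the 2 values shown sit. Compound 3 `O=C(NC(=S)N1CCc2c(OCCCCCOc3ccc(Cl)cc3)cccc21)c1cc2ccccc2s1` differs from compound 2 by 1-benzothiophen-2-yl in place of phenethyl on a carbonyl carbon. Within the data shown here, no measured step with a readable size bears on this change. Since both measured values sit at the limit, compound 3 is expected to stay there as well, an expected step that the limit leaves unreadable from compound 2 to compound 3. Compound 3 is thus estimated at 60000 nM, between 20000 nM and 150000 nM.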

Compound 3, half-maximal cytotoxic concentration: > 50000 nM
Compound 3 gave a limit, no number (the forecaster's own chance of this, stated with the estimate: 80%); the middle value does not contradict the limit.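

No step can be read among compound 1, compound 2 and compound 3, because each gives only a limit in this assay: the limit of > 50000 nM in this assay, at which 3 of the 3 values shown sit.

The compounds shown leave open at what concentration any of the three becomes cytotoxic, and whether the group on the amide-type nitrogen matters for this.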